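Removing the dimethylamino group from compound 1

The source may report more compounds than this note shows. Statements on the series, on what has been measured and on what is new or still open speak of the compounds shown alone.

In an ADME assay on a cell-free system (plasma, Mus musculus) (a lower number here means a smaller unbound share, a higher number a larger unbound share of the compound), compound 1 (`CN(C)S(=O)(=O)c1ccc(F)c(C#Cc2cc(Cl)ccc2OCC(=O)O)c1`) gives 0.029 as its result, the higher of the two numbers available. Compound 3 (`Cc1ccc(S(=O)(=O)N(C)C)cc1C#Cc1cc(Cl)ccc1OCC(=O)O`) gives 0.01 as its result. For compound 2 (`Cc1ccc(S(=O)(=O)N2CCCCC2C)cc1C#Cc1cc(Cl)ccc1OCC(=O)O`) the entry reads "not determined" (no result reported) and so offers no number to compare.

Compound 4 (`CS(=O)(=O)c1ccc(F)c(C#Cc2cc(Cl)ccc2OCC(=O)O)c1`) has not yet been measured. It keeps the core of compound 1 but has methyl in place of dimethylamino on a sulfonyl sulfur, which turns dimethylsulfamoyl into methylsulfonyl.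

Among the compounds with values here, only one measured step bears on this, and only indirectly. That step (a 2.9-fold lower number from compound 1 to compound 3 (0.46 log units; beyond the scatter)) swaps fluoro for methyl on an aromatic carbon, so it does not test the sulfonyl change. It shows just that one small swap can shift this number modestly. A step of similar modest size is therefore expected, and the upward direction is a tentative call that the data cannot settle. The estimated step is a 1.6-fold higher number from compound 1 to compound 4 (0.19 log units; within the scatter) in this tentative direction. Compound 4 is expected at 0.045 with an estimated range from 0.02 to 0.1 in this assay for now.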

Compound 4, unbound fraction: 0.054
Estimate against measurement, compound 4: 1.2-fold (0.08 log units) below; measured number inside the range.
By their numbers in this assay, from the lowest: compound 3; then compounds 1 and 4 (each within the scatter of the next).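

Within the data shown here, this is the first direct test of the group on the sulfonyl sulfur. In this assay the step of a 1.9-fold higher number from compound 1 to compound 4 (0.27 log units; within the scatter) comes with methyl in place of dimethylamino, so dimethylsulfamoyl and methylsulfonyl cannot be told apart at this position, and the dimethylamino group, with 3 heavy atoms against 1 for methyl, is not needed to keep the number at the level of compound 1. No measured property of these compounds is available to explain this result.

Still open, as far as these compounds go, is how an ethyl chain, a cyclopropyl ring or a plain amino group on the sulfonyl sulfur would read. Also open is whether the same change would give a similar result with methyl in place of fluoro on the aromatic carbon, as in compound 3, for which no methylsulfonyl partner is shown.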